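Cyclohexyl to aryl swaps and cytotoxicity in this series

The compounds below may be only part of what the source reports. "The series", "measured", "known", "first", "only" and "open" are said of these compounds alone.

Compound 1 `COc1nc(C2CCCCC2)ccc1[C@@H](c1ccccc1)[C@@](O)(CCN(C)C)c1cccc2ccccc12` in a toxicity assay on Vero cells (Chlorocebus sabaeus) for cytotoxicity (on this read-out lower numbers stand for higher toxicity in this test and higher numbers for lower toxicity in this test), gives 32.3 ug/mL.
Compound 2 `COc1nc(-c2ccc(F)cc2)ccc1[C@@H](c1ccccc1)[C@@](O)(CCN(C)C)c1cccc2ccccc12` in this assay gives > 50 ug/mL, which is a limit of the assay, not a number.

Compound 2 thus sits at the limit of > 50 ug/mL in this assay, at which 1 of the 2 values shown sits. Among the measured compounds shown here, the one measured step, an at least 1.5-fold higher number from compound 1 to compound 2 (0.18 log units; that floor lies within the scatter), has a floor within the scatter. Compound 3 `COc1nc(-c2ccc(OC(F)(F)F)cc2)ccc1[C@@H](c1ccccc1)[C@@](O)(CCN(C)C)c1cccc2ccccc12` differs from compound 2 by trifluoromethoxy in place of fluoro on an aromatic carbon. For the measured compounds named here, no measured step covers this change, so for compound 3 a step of an at least 1.2-fold lower number from compound 2 to compound 3 (0.09 log units; that floor lies within the scatter) in this assay is expected, not beyond the scatter. Compound 3 is estimated at 40 ug/mL, ranging from 18 ug/mL to 90 ug/mL.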

Compound 3, half-maximal cytotoxic concentration: > 50 ug/mL
Compound 3 gave a limit, no number (the forecaster's own chance of this, stated with the estimate: 40%); middle value at least 1.2-fold (0.09 log units) away from the limit.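

In this assay compound 3 also reads as a limit, so trifluoromethoxy in place of fluoro on the aryl ring leaves the reading at the ceiling: the limit of > 50 ug/mL in this assay, at which 2 of the 3 values shown sit. The step between compound 2 and compound 3 cannot be read, as both values are limits. Cyclohexyl to 4-(trifluoromethoxy)phenyl gives an at least 1.5-fold higher number from compound 1 to compound 3 (0.18 log units; that floor lies within the scatter), so a second aryl swap shows the same direction, but its floor does not go beyond the scatter.

As far as these compounds go, the true size of either aryl swap remains open. Also open, from the compounds shown here alone, is whether an amine or a carboxylic acid in place of trifluoromethoxy would bring a number under the limit.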